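This account rests on a few compounds, and the source may have more. Where it says the series, first, only, none or still open, it means among the compounds named here.

Compound 3 `O=S(=O)(NCCCNCc1ccc(-c2ccccc2)cc1)c1cc(C(F)(F)F)cc(C(F)(F)F)c1` and compound 2 `O=S(=O)(NCCNCc1ccc(-c2ccccc2)cc1)c1cc(C(F)(F)F)cc(C(F)(F)F)c1` carry the same sulfonamide end; how their two cores differ is not broken down here. In a functional assay on A2780 cells (Homo sapiens) for inhibition, read by MTT assay, with a stated time of 72 h (a lower number here means a stronger inhibitor of growth, a higher number a weaker inhibitor of growth), compound 3 gives 2600 nM, and compound 2 gives 2600 nM, the two values showing no change at the digits printed. Compound 1 `CC(C)(C)c1ccc(CNCCCNS(=O)(=O)c2cc(C(F)(F)F)cc(C(F)(F)F)c2)cc1` arises from compound 3 by tert-butyl in place of phenyl on an aromatic carbon, and the step of a 1.1-fold higher number from compound 3 to compound 1 (0.05 log units; within the scatter) stays within the scatter, so compound 1 gives 2900 nM. All three measured numbers thus sit together, with none standing apart from the others.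

Compound 4 `CC(C)(C)c1ccc(CNCCNS(=O)(=O)c2cc(C(F)(F)F)cc(C(F)(F)F)c2)cc1` is related to compound 2 by tert-butyl in place of phenyl on an aromatic carbon; the place is the same as before, so this is the same change made on the other core. The expectation for compound 4 rests on the pair compound 3 and compound 1, where this change gave a 1.1-fold higher number from compound 3 to compound 1 (0.05 log units; within the scatter). From compound 2 the step is expected to be similarly small, a 1.1-fold higher number from compound 2 to compound 4 (0.03 log units; within the scatter). Compound 4 is therefore expected to give about 2800 nM, most likely between 1400 nM and 5600 nM.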

Compound 4, concentration for 50% growth inhibition: 14000 nM
The estimate for compound 4 lay 5.0-fold (0.70 log units) below the measured number; measured number outside the range, above it.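

In this assay, tert-butyl in place of phenyl on an aromatic carbon does not carry over unchanged from one core to the other: the same change on two cores in this assay, a 1.1-fold higher number (0.05 log units; within the scatter) from compound 3 to compound 1 and a 5.4-fold higher number (0.73 log units; beyond the scatter) from compound 2 to compound 4, 4.8-fold (0.68 log units) apart, beyond the scatter of two such steps

On the core of compound 2 the change is a real loss, a 5.4-fold higher number from compound 2 to compound 4 (0.73 log units; beyond the scatter), so the near-silent result on the core of compound 3 is no safe guide to this change on a related core in this series. This rests on a single pair per core and shows only that the outcome of this change depends on the core; it gives no cause for the gap and no rule for other groups or other cores.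

The compounds shown leave open whether a methyl group, a methoxy group or a carboxylic acid at the same place would separate the two cores in the same way. As far as these compounds go, it also remains open whether a core with a longer chain would follow the core of compound 2 or that of compound 3 when phenyl gives way to tert-butyl.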